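The source may hold more compounds than are shown below. What is called first, only, known or untested is meant among the compounds shown, and "the series" means these compounds.

Measured so far:
- compound 1 `COc1cc(-c2cc(/C=C/C(=O)c3ccc(N)cc3)[nH]n2)cc(OC)c1OC`: 111%
- compound 2 `COc1cc(-c2cc(/C=C/C(=O)c3ccc(Cl)c(Cl)c3)[nH]n2)cc(OC)c1OC`: 88%

In a functional assay on SK-MEL-2 cells (Homo sapiens) for cytotoxicity, read by sulforhodamine B assay, with a stated time of 48 h, tested at 0.1 uM (on this read-out higher numbers stand for a weaker effect at the one concentration tested and lower numbers for a stronger effect), compound 1 gives 111%, the highest of the two numbers recorded. Within the data shown here, its nearest neighbour is compound 2, reached by the one measured step, a number 23 percentage points lower from compound 1 to compound 2 (beyond the scatter), where 3,4-dichlorophenyl replaces 4-aminophenyl on the carbonyl carbon.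

Compound 3 `COc1ccc(-c2cc(/C=C/C(=O)c3ccc(N)cc3)[nH]n2)cc1OC` shares the core of compound 1 and differs from it in one place: hydrogen in place of methoxy on an aromatic carbon. Among the measured compounds shown here, the only measured step alters the ring on the carbonyl side, not the methoxy-bearing ring, so no recorded step bears directly on removing a methoxy group. Both measured compounds show little effect at this concentration, and with nothing pointing elsewhere the expectation is a step within the scatter, a number 6 percentage points lower from compound 1 to compound 3 (within the scatter), in no firm direction. Compound 3 is therefore estimated to give 105%, expected to fall between 85% and 125%.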

Compound 3, a percentage reported as activity, at one concentration (the size of the read-out at that concentration, not a potency): 109%
Beside the measured number, compound 3's estimate is 4 percentage points below it; measured number inside the range.
By their numbers in this assay, from the lowest: compound 2; then compounds 3 and 1 (each within the scatter of the next).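

Among these compounds, the earlier step altered only the group on the carbonyl carbon, whereas this one gives the first reading on the methoxy-bearing ring: in this assay, hydrogen in place of methoxy gives a number 2 percentage points lower from compound 1 to compound 3 (within the scatter). At this single concentration, compound 1 and compound 3 cannot be told apart, so this methoxy group shows no measurable contribution to the read-out in the aminophenyl series. Nothing available explains this result.

This is one low concentration at which both compounds show little effect. The result cannot establish that the methoxy group is unimportant at higher concentrations. From the compounds shown here alone, it also remains open whether a hydroxy group, an ethoxy group or a fluorine atom at this carbon would behave like hydrogen, and whether removing the methoxy group would have the same outcome alongside the 3,4-dichlorophenyl group of compound 2.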